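A few compounds are considered here, and "the series" means these few. Any claim that something is new, unique, unknown or untested is made for them only; others in the source may bear on it.

Working notes on the series. Compound 1 `Cc1ccc(NC(=O)Nc2cc(-c3ccccc3C(=O)O)ccc2NC2CCCCC2)cc1` and compound 2 `Cc1ccc(NC(=O)Nc2cc(-c3ccccc3C(=O)NS(C)(=O)=O)ccc2N(CC(C)C)CC(C)C)cc1` share the same core and have been run in an assay on HeLa cells for inhibition of Indoleamine 2,3-dioxygenase 1 (Homo sapiens), with stated times of 1 h and 18 h; a lower number here means a stronger inhibitor, a higher number a weaker inhibitor. Compound 1 gives 504 nM in this assay. Within the data shown here, compound 2 gives 661 nM in this assay, the higher of the two numbers so far, though its gap to compound 1 lies within the scatter of repeated runs, so no order between the two can be read from these values.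

Compound 3 `Cc1ccc(NC(=O)Nc2cc(-c3ccccc3NS(C)(=O)=O)ccc2N(CC(C)C)CC(C)C)cc1` is the next member and has not yet been measured. It differs from compound 2 by methanesulfonamido in place of (methylsulfonyl)carbamoyl on an aromatic carbon; the change removes the carbonyl of the (methylsulfonyl)carbamoyl group while the methanesulfonamido group keeps one hydrogen-bond donor at the same place.

Among the measured compounds shown here, no step between measured compounds bears on this change, so the expectation rests only on the two values at hand. The step from compound 2 to compound 3 is expected to be modest and, if anything, toward a higher number, estimated as a 1.4-fold higher number from compound 2 to compound 3 (0.16 log units; within the scatter). For compound 3 in this assay the estimate is 950 nM, with a range from 350 nM to 2600 nM.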

Compound 3, half-maximal inhibitory concentration: > 1000 nM
Compound 3: a limit, no number; the forecaster's own chance of this, stated with the estimate: 3%; middle value at least 1.0-fold (0.02 log units) away from the limit.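

Compound 3 carries no number in this assay, only a limit: the limit of > 1000 nM in this assay, at which 1 of the 3 values shown sits. This gives the series its first step that changes one place alone, on an aromatic carbon ortho to a large group, and it reads as an at least 1.5-fold higher number from compound 2 to compound 3 (0.17 log units; that floor lies within the scatter). Methanesulfonamido in place of (methylsulfonyl)carbamoyl therefore brings no gain here, although the true size of the step remains unfixed.

Compound 1 and compound 2 differ in more than one place, so the parts played by the carboxylic acid and the (methylsulfonyl)carbamoyl group at this position cannot be separated from the change in the amine. Going by these compounds, it also remains open how a primary carboxamide, a tetrazole or an ethanesulfonamido group would read at this place on the core of compound 2.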